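Changing the Substituent Beside the Thiophene Sulfur

This account rests on a few compounds, and the source may have more. Where it says the series, first, only, none or still open, it means among the compounds named here.

Compound 2 `COc1ccc(Cc2sc3c(c2C(=O)N[C@@H](C)c2ccc(C(=O)O)cc2)CCOC3)cc1` is the reference point of this small set. In a functional assay on CHO/Galpha16 cells for antagonist activity at prostaglandin E2 receptor EP4 subtype (Homo sapiens), read by calcium flux, with a stated time of 15 min (on this read-out higher numbers stand for weaker inhibition and lower numbers for stronger inhibition), compound 2 gives 2.1 nM, the only numerical result among the two measured compounds. Compound 1 `C[C@H](NC(=O)c1c(NC(=O)c2ccc(F)cc2)sc2c1CCOC2)c1ccc(C(=O)O)cc1` carries a ((4-fluorophenyl)carbonyl)amino group at the same position; in this assay compound 1 reaches only a limit of the assay, > 1000 nM, and that limit is what the limit of > 1000 nM in this assay, at which 1 of the 2 values shown sits, records. Among the measured compounds shown here, the single measured step, an at least 470-fold lower number from compound 1 to compound 2 (2.67 log units; beyond the scatter), shows that this position tolerates large swings in potency.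

Compound 3 `C[C@H](NC(=O)c1c(C#Cc2ccc(=O)[nH]c2)sc2c1CCOC2)c1ccc(C(=O)O)cc1` has not yet been measured. It differs from compound 2 by a group of 9 heavy atoms (7 carbon, 1 nitrogen, 1 oxygen; one six-membered aromatic ring with 1 hetero atom) in place of a group of 9 heavy atoms (8 carbon, 1 oxygen; one six-membered aromatic ring of carbon only), on an aromatic carbon. The measured step from compound 1 to compound 2 bears on it only indirectly, since the entering group resembles neither the acylamino of compound 1 nor the 4-methoxybenzyl of compound 2. Given that a change at this position produced an at least 470-fold lower number from compound 1 to compound 2 (2.67 log units; beyond the scatter), some loss in this assay is expected for compound 3, estimated as a 19-fold higher number from compound 2 to compound 3 (1.28 log units; beyond the scatter). Compound 3 is therefore expected to give about 40 nM, with a plausible range from 5 nM to 600 nM.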

Compound 3, half-maximal inhibitory concentration: 642 nM
The estimate for compound 3 lay 16-fold (1.21 log units) below the measured number; the measured number lies above the stated range.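

Replacing 4-methoxybenzyl with a group of the same 9 heavy atoms, carrying one six-membered aromatic ring with 1 hetero atom and 1 triple bond outside aromatic rings, gives a 310-fold higher number from compound 2 to compound 3 (2.49 log units; beyond the scatter) in this assay, so at this place next to the ring sulfur a matching heavy-atom count does not preserve the low number of compound 2. The other new step, an at least 1.5-fold lower number from compound 1 to compound 3 (0.19 log units; that floor lies within the scatter), is only a floor, so it sets no order between the entering group and ((4-fluorophenyl)carbonyl)amino, and among the three groups shown only 4-methoxybenzyl gives a low number. Nothing in the data shown accounts for the rise in the number from compound 2 to compound 3.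

As far as these compounds go, the triple bond, the hetero atom in the ring and the double bond outside aromatic rings all enter together in compound 3, so it remains open which of them matters, or whether the difference in hydrogen-bond donors does. A plain benzyl, a 4-aminobenzyl or a phenyl group joined through the same triple bond would each separate these features at this position.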